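The compounds below may be only part of what the source reports. "The series", "measured", "known", "first", "only" and "open" are said of these compounds alone.

Measured compounds:
- compound 1 `Cc1nc(NCCCNS(C)(=O)=O)nc2ccc(NC(=O)/C=C/c3ccc(OC(F)(F)F)cc3)cc12`: "not determined" (no result reported) in an ADME assay on microsomes from liver (Homo sapiens) for metabolic stability, with a stated time of 30 min; a lower number here means that less of the compound is left, a higher number that more of the compound is left
- compound 2 `Cc1nc(N2CCC(N3CCCS3(=O)=O)CC2)nc2ccc(NC(=O)/C=C/c3ccc(OC(F)(F)F)cc3)cc12`: 85%
- compound 3 `C/C(=C\C(=O)Nc1ccc2nc(N3CCC(N4CCCC4=O)CC3)nc(C)c2c1)c1ccc(OC(F)(F)F)cc1`: "not determined" (no result reported)

Compound 2 stands alone on the numbers. In this assay, going by the values given here, compound 2 gives 85%, a high fraction remaining, while compound 1 gives "not determined" (no result reported) and compound 3 gives "not determined" (no result reported) in this assay, so nothing can be said of how the three compare, and no step between measured compounds exists in this set.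

Compound 4 `COCC(=O)NC1CCN(c2nc(C)c3cc(NC(=O)/C=C/c4ccc(OC(F)(F)F)cc4)ccc3n2)CC1` is the next to be measured. Against compound 2 the change is a group of 6 heavy atoms (3 carbon, 1 nitrogen, 2 oxygen; no ring) in place of a group of 7 heavy atoms (3 carbon, 1 nitrogen, 2 oxygen, 1 sulfur; one five-membered non-aromatic ring with 2 hetero atoms), on a saturated ring carbon. The group that leaves and the group that enters each carry two hydrogen-bond acceptors; the entering group brings one hydrogen-bond donor and no ring, and the rest of the molecule, including the shared core and the amide-linked side, stays the same.

Among the compounds with values here, with a single anchor value and no measured step to guide the size, the step of a number 10 percentage points lower from compound 2 to compound 4 (within the scatter) is expected to be small and, if anything, downward, likely within the scatter of repeated runs, but with wider uncertainty than a measured pair would allow. Compound 4 is therefore expected to give 75% in this assay, with a range from 55% to 92%.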

Compound 4, percent of the compound remaining: 58%
Estimate against measurement, compound 4: 17 percentage points above, within the range that was stated.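

In this assay, the saturated ring carbon three ring bonds from the ring nitrogen now has its first measured step: a number 27 percentage points lower from compound 2 to compound 4 (beyond the scatter) shows that the fraction remaining depends on the group carried at this position. The change removes the five-membered non-aromatic ring with 2 hetero atoms and brings in the open ((methoxymethyl)carbonyl)amino group, so the loss of the ring, the loss of sulfur and the gain of a hydrogen-bond donor all fall within this single step and cannot be separated. Nothing measured here accounts for the size or direction of the step.

Which of these differences carries the step remains open, and a closed ring without sulfur or an open methanesulfonylamino group at this position would be needed to separate them. Also open is where a carboxylic acid or a simple primary amine on the same ring carbon would fall relative to compound 2 and compound 4, since the series shown offers only this one pair with numbers.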